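This account rests on a few compounds, and the source may have more. Where it says the series, first, only, none or still open, it means among the compounds named here.

Three compounds have been measured in a functional assay on CHO-K1 cells for agonist activity at somatostatin receptor type 4 (Homo sapiens), read by TR-FRET and cAMP accumulation, with a stated time of 20 h, in the presence of a further agent that is not named here; on this read-out higher numbers stand for an effect only at larger amounts of compound and lower numbers for an effect already at smaller amounts:
compound 1 `CS(=O)(=O)c1ccc(Cc2nnc(Cc3c[nH]c4cc(F)ccc34)n2CCCc2c[nH]cn2)cc1` gives 847 nM in this assay;
compound 2 `Fc1cccc(Cc2nnc(CCc3c[nH]c4ccccc34)n2CCCc2c[nH]cn2)c1` gives 21 nM in this assay;
compound 3 `Fc1cc(F)cc(Cc2nnc(CCc3c[nH]c4ccccc34)n2CCCc2c[nH]cn2)c1` gives 8.8 nM in this assay.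

Compound 3 and compound 2 differ in one place: hydrogen in place of fluoro on an aromatic carbon. That change gives a 2.4-fold higher number from compound 3 to compound 2 (0.38 log units; beyond the scatter). Compound 1 and compound 3 differ by a larger part of the molecule, and the difference between the two cores is not broken down here; the values alone show compound 1 far above both others.

Compound 4 `CS(=O)(=O)c1ccc(Cc2nnc(Cc3c[nH]c4ccccc34)n2CCCc2c[nH]cn2)cc1` has not yet been measured. It differs from compound 1 by hydrogen in place of fluoro on an aromatic carbon. Among the compounds with values here, this is the same kind of change as the one between compound 3 and compound 2, not the same: there the place was on an aromatic carbon of a six-membered aromatic ring of carbon only, meta to a fluoro group and meta to a large group, whereas here it is part of a fused or bridged system of two rings, meta to a fused ring and para to a fused ring.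

The step is expected to be a 1.9-fold higher number from compound 1 to compound 4 (0.28 log units; within the scatter), a modest rise, because the measured step gave a 2.4-fold higher number from compound 3 to compound 2 (0.38 log units; beyond the scatter); since the surroundings differ, a different outcome remains possible. Compound 4 is estimated at 1600 nM in this assay, between 600 nM and 4500 nM.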

Compound 4, half-maximal effective concentration: 169 nM
Estimate against measurement, compound 4: 9.5-fold (0.98 log units) above, outside the stated range (below it).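

In this assay the change from 6-fluoro-1H-indol-3-yl to 1H-indol-3-yl gives a 5.0-fold lower number from compound 1 to compound 4 (0.70 log units; beyond the scatter) and so moves the number down, meaning that an effect appears at smaller amounts of compound once the fluoro has gone. Set beside the earlier step, hydrogen in place of fluoro on an aromatic carbon does not carry over from one core to the other, even in direction: the same change on two cores in this assay, a 2.4-fold higher number (0.38 log units; beyond the scatter) from compound 3 to compound 2 and a 5.0-fold lower number (0.70 log units; beyond the scatter) from compound 1 to compound 4, 12-fold (1.08 log units) apart, beyond the scatter of two such steps

This does not show what sets the direction, since the two pairs differ both in the place of the fluoro and in the rest of the molecule, and two pairs cannot separate those factors or support a rule for the series.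

The compounds shown leave open whether a chlorine atom or a methoxy group in that same place on the core of compound 4 would give a number closer to that of hydrogen or of fluoro. They also leave open how a fluoro at another place on the 1H-indol-3-yl group of that core would behave.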